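The source may report more compounds than this note shows. Statements on the series, on what has been measured and on what is new or still open speak of the compounds shown alone.

Measured so far in a functional assay on HepG2 cells (Homo sapiens) for inhibition, read by MTT assay, with a stated time of 72 h, tested at 30 uM; on this read-out lower numbers stand for less inhibition of growth and higher numbers for more inhibition of growth at the one concentration tested:

- compound 1 `C=CCc1ccc(OCc2cn(-c3cccc([N+](=O)[O-])c3)nn2)c(O)c1`: 15.2%
- compound 2 `C=CCc1cc(O)c(O)c(CN2CCC(C)CC2)c1`: 57.6%
- compound 3 `C=CCc1ccc(OCc2cn(-c3ccccc3CO)nn2)c(O)c1`: 4.2%

Among these three compounds, compound 2 stands highest, at 57.6%. The gaps separating it from compound 1 and from compound 3 both lie beyond the usual scatter of repeated measurements. Compound 1 and compound 3 have a different structure from compound 2 in more than one place, so neither shows what a single small change does to compound 2.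

The next compound, compound 4 `C=CCc1cc(O)c(O)c(CN2CCC(CO)CC2)c1`, has not yet been measured in this assay. It departs from compound 2 by one change: hydroxy in place of hydrogen on a saturated chain carbon bound to a saturated ring carbon. This is hydroxy in place of hydrogen on a saturated chain carbon bound to a saturated ring carbon, which can also be read as methyl to hydroxymethyl.

For the measured compounds named here, no measured pair in this set isolates that change, so the expectation rests on little more than the standing of compound 2 at 57.6%, the top of a small set. A modest fall seems more likely than a rise, though no change beyond the scatter remains possible. The expected size of the move is a number 12.6 percentage points lower from compound 2 to compound 4 (beyond the scatter). For compound 4 the estimated value is 45%, with an expected range of 25% to 65%.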

Compound 4, percent growth inhibition at one concentration: 4.7%
The estimate for compound 4 lay 40.3 percentage points above the measured number; the whole stated range lies above it.
By their numbers in this assay, from the lowest: compounds 3 and 4 (each within the scatter of the next); then compound 1; then compound 2.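

In this assay, hydroxy in place of hydrogen on a saturated chain carbon bound to a saturated ring carbon, which also reads as methyl to hydroxymethyl, gives a number 52.9 percentage points lower from compound 2 to compound 4 (beyond the scatter). For the compounds shown here, this is the first pair in the set that differs in one place, and it shows that this one change, a single added oxygen atom, is enough to take away most of the growth inhibition seen with compound 2 at the one concentration tested. Nothing available accounts for the size of this step, so the reason for it remains unknown.

A single pair cannot tell whether the loss is specific to hydroxymethyl or would also follow from other groups in its place, such as aminomethyl, a carboxylic acid, methoxymethyl or a longer chain such as ethyl. It also leaves open whether the same change would have a step of similar size on another core, and whether the fall seen at this one concentration would hold at other concentrations.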